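Tetrazole aryl swap toward pyridin-2-yl in the octylphenoxy series

A few compounds are considered here, and "the series" means these few. Any claim that something is new, unique, unknown or untested is made for them only; others in the source may bear on it.

Two compounds of the series have numbers in an assay on microsomes from brain for inhibition of Fatty-acid amide hydrolase 1 (Rattus norvegicus), read by fluorescence and HPLC, with a stated time of 60 min; on this read-out lower numbers stand for stronger inhibition and higher numbers for weaker inhibition. Compound 1 `CCCCCCCCc1ccc(OCC(=O)Cn2nnc(-c3ccccc3Cl)n2)cc1` gives 32 nM in this assay. For the measured compounds named here, compound 2 `CCCCCCCCc1ccc(OCC(=O)Cn2nnc(-c3ccc(S(=O)(=O)N(C)C)cc3)n2)cc1` gives 590 nM in this assay and stands at the higher of the two numbers, with compound 1 as its only neighbour. Going by the values given here, the one measured step, an 18-fold higher number from compound 1 to compound 2 (1.27 log units; beyond the scatter), is large and lies beyond the scatter.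

Compound 3 `CCCCCCCCc1ccc(OCC(=O)Cn2nnc(-c3ccccn3)n2)cc1` is not yet measured. It differs from compound 2 in one place: pyridin-2-yl in place of 4-(dimethylsulfamoyl)phenyl on an aromatic carbon. The aryl group on the tetrazole carbon is again exchanged, so the step from compound 1 to compound 2 is the only one that bears on it, and it shows that this position moves the number by a wide margin. The entering pyridin-2-yl carries no substituent of the kind that leaves, so a move back toward the number of compound 1 is expected, though the data do not fix how far. For compound 3 the estimate in this assay is 120 nM, within 30 nM to 500 nM. The expected step is a 4.9-fold lower number from compound 2 to compound 3 (0.69 log units; beyond the scatter), a lower number beyond the scatter.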

Compound 3, half-maximal inhibitory concentration: 18 nM
Estimate against measurement, compound 3: 6.7-fold (0.82 log units) above, and the stated range ends above it.
By their numbers in this assay, from the lowest: compounds 3 and 1 (each within the scatter of the next); then compound 2.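

The exchange at this aromatic carbon, two ring bonds from the ring nitrogen, gives a 33-fold lower number from compound 2 to compound 3 (1.52 log units; beyond the scatter) in this assay and so shows that the high number of compound 2 belongs to 4-(dimethylsulfamoyl)phenyl and not to the shared core. The series also shows a 1.8-fold lower number from compound 1 to compound 3 (0.25 log units; within the scatter) for the two groups without the sulfamoyl substituent, so pyridin-2-yl, with its hetero atom in the ring, and 2-chlorophenyl, with a carbon-only ring and a chlorine, cannot be told apart at this position. No measurement at hand bears on what in the leaving group accounts for the large step.

The leaving group differs from pyridin-2-yl in size, in ring type and in its substituent all at once, so the compounds shown do not separate these changes; unsubstituted phenyl, 4-chlorophenyl or pyridin-3-yl at the same carbon would begin to do so. Also open, going by these compounds, is whether the equivalence of pyridin-2-yl and 2-chlorophenyl holds when the octyl chain gives way to a hexyl chain.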